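The compounds below may be only part of what the source reports. "The series", "measured", "known", "first", "only" and "open" are said of these compounds alone.

Compound 3 `CN(C)c1ccc(C2CC(c3ccc(-n4ccnc4)cc3)=NN2C(=O)c2ccc(F)cc2)cc1` gives 7.1% in a functional assay on HCC1806 cells (Homo sapiens) for inhibition, read by sulforhodamine B assay, tested at 10 uM (on this read-out lower numbers stand for less inhibition and higher numbers for more inhibition at the one concentration tested (going by the name of the read-out)), the second highest of three numbers. Within the data shown here, compound 2 `CC(=O)N1N=C(c2ccc(-n3ccnc3)cc2)CC1c1ccc(N(C)C)cc1` gives -9.7%, and the one measured step, a number 16.8 percentage points higher from compound 2 to compound 3 (beyond the scatter), came from putting a 4-fluorophenyl in place of methyl on a carbonyl carbon. Compound 1 `CN1CCN(c2ccc(C3=NN(S(=O)(=O)c4ccc(C#N)cc4)C(c4ccc(N(C)C)cc4)C3)cc2)CC1`, which carries a (4-cyanophenyl)sulfonyl on an amine nitrogen in a ring, gives 99.8%. Compound 4 `CN(C)c1ccc(C2CC(c3ccc(-n4ccnc4)cc3)=NN2S(=O)(=O)c2ccc(C#N)cc2)cc1` differs from compound 3 in one place: (4-cyanophenyl)sulfonyl in place of (4-fluorophenyl)carbonyl on an amine nitrogen in a ring. Among the measured compounds shown here, no measured step tests this exchange directly, and the measured step was only modest. The value of compound 1 in this assay, however, points to a substantial rise once the same group is present. A large upward step is expected, a number 77.9 percentage points higher from compound 3 to compound 4 (beyond the scatter). Compound 4 is estimated at 85%, ranging from 50% to 100%.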

Compound 4, a percentage reported as inhibition, at one concentration (the size of the read-out at that concentration, not a potency): 4.7%
Estimate against measurement, compound 4: 80.3 percentage points above; the measured number lies below the stated range.
By their numbers in this assay, from the lowest: compound 2; then compounds 4 and 3 (each within the scatter of the next); then compound 1.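

The (4-cyanophenyl)sulfonyl on the amine nitrogen in a ring is not enough on its own in this assay: replacing (4-fluorophenyl)carbonyl gives a number 2.4 percentage points lower from compound 3 to compound 4 (within the scatter) and replacing acetyl gives only a number 14.4 percentage points higher from compound 2 to compound 4 (beyond the scatter) here. With that group held fixed, the substituent on the aromatic carbon separates the high value from the low one, since 1H-imidazol-1-yl in place of 4-methylpiperazin-1-yl gives a number 95.1 percentage points lower from compound 1 to compound 4 (beyond the scatter) in this pair. No measurement here explains this difference. Going by these compounds, it remains open whether 4-methylpiperazin-1-yl would also raise the number with a (4-fluorophenyl)carbonyl on the ring nitrogen. On these data alone, it is equally open whether another amine on that aromatic carbon, such as morpholine, would do the same.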